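Aryl swap on compound 1: expected activity of compound 4

A few compounds are considered here, and "the series" means these few. Any claim that something is new, unique, unknown or untested is made for them only; others in the source may bear on it.

Measured compounds:
compound 1 `N#CC1=C(N)Oc2c(c3nc4ccccc4nc3c3ccccc23)C12C(=O)N(Cc1cnnn1-c1ccccc1Cl)c1ccccc12` — 42600 nM
compound 2 `COc1ccccc1-n1nncc1CN1C(=O)C2(C(C#N)=C(N)Oc3c2c2nc4ccccc4nc2c2ccccc32)c2ccccc21` — > 50000 nM
compound 3 `N#CC1=C(N)Oc2c(c3nc4ccccc4nc3c3ccccc23)C12C(=O)N(Cc1cnnn1-c1ccc([N+](=O)[O-])cc1)c1ccccc12` — > 50000 nM

All three were tested in a functional assay on A549 cells (Homo sapiens) for antiproliferative activity, read by MTT assay, with a stated time of 48 h; a higher number here means a weaker inhibitor, a lower number a stronger inhibitor. Among the compounds with values here, compound 1 gives 42600 nM, the only plain number in the set. For compound 2 the value > 50000 nM is a limit of the assay, not a number. For compound 3 the value > 50000 nM is likewise a limit. Compound 1 therefore stands as the sole reference point, with the other two sitting at the limit of > 50000 nM in this assay, at which 2 of the 3 values shown sit.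

Compound 4 `N#CC1=C(N)Oc2c(c3nc4ccccc4nc3c3ccccc23)C12C(=O)N(Cc1cnnn1-c1ccc(S(N)(=O)=O)cc1)c1ccccc12` is not yet measured. It differs from compound 1 as follows: 4-sulfamoylphenyl in place of 2-chlorophenyl on an aromatic nitrogen.

Within the data shown here, two measured steps bear on this change, both of which replace the 2-chlorophenyl of compound 1 with another aryl on the same aromatic nitrogen: an at least 1.1-fold higher number from compound 1 to compound 2 (0.06 log units; that floor lies within the scatter) and an at least 1.1-fold higher number from compound 1 to compound 3 (0.06 log units; that floor lies within the scatter). The step from compound 2 to compound 3 is a step that the two limits leave unreadable from compound 2 to compound 3. With both limits in place, neither replacement improved on compound 1, and the floor of each step lies within the scatter.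

For compound 4 the expected step is a 1.4-fold higher number from compound 1 to compound 4 (0.15 log units; within the scatter), with a real chance that only a limit is reported. The estimate for compound 4 is 60000 nM, with a range from 25000 nM to 150000 nM.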

Compound 4, half-maximal inhibitory concentration: > 50000 nM
Compound 4: a limit, no number; the forecaster's own chance of this, stated with the estimate: 65%; the middle value lies beyond the limit too.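

In this assay compound 4 returns a limit and not a number, the same outcome as before but now for a replacement of the 2-chlorophenyl that brings a hydrogen-bond donor and hydrogen-bond acceptors, which the 2-chlorophenyl lacks. Within the data shown here, the one readable step is an at least 1.1-fold higher number from compound 1 to compound 4 (0.06 log units; that floor lies within the scatter); it shows no gain from this change at this position, and it does not establish a real loss either. The steps among compound 2, compound 3 and compound 4 cannot be read, and the series now gathers at a single ceiling: the limit of > 50000 nM in this assay, at which 3 of the 4 values shown sit.

What the compounds shown leave open is whether any aryl group on this nitrogen gives a clearly lower number than compound 1, and whether the chloro substituent of compound 1 contributes at all, since its one plain number has no readable step beyond the scatter. A plain phenyl, a pyridine ring or an aryl group bearing a carboxylic acid or an amine on the same nitrogen could show whether this position can move the number at all.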